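Lengthening the hydroxycarbamoyl chain: working notes

The source may report more compounds than this note shows. Statements on the series, on what has been measured and on what is new or still open speak of the compounds shown alone.

Measured so far:
- compound 1 `O=C(O)c1ccc2c(c1)no[n+]2[O-]` gives "not determined" (no result reported)
- compound 2 `O=C(CCCOC(=O)c1ccc2c(c1)no[n+]2[O-])NO` gives 27100 nM

For the measured compounds named here, in a functional assay on ES2 cells (Homo sapiens) for inhibition, read by MTT assay, with a stated time of 48 h (a lower number here means a stronger inhibitor, a higher number a weaker inhibitor), compound 2 gives the only number so far (27100 nM). It therefore has no measured neighbour to be ranked against, since compound 1 offers no result for comparison.

Compound 3 `O=C(CCCCOC(=O)c1ccc2c(c1)no[n+]2[O-])NO` has yet to be measured. Its difference from compound 2 is (hydroxycarbamoyl)methyl in place of hydroxycarbamoyl on a saturated chain carbon, three bonds along the chain from an oxygen next to a carbonyl group and amounts to (hydroxycarbamoyl)methyl in place of hydroxycarbamoyl on a saturated chain carbon, three bonds along the chain from an oxygen next to a carbonyl group. The shared core and ester stay unchanged.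

Going by the values given here, no step between measured compounds is available to set the size of this change, so any expectation here is weakly founded. A modest shift towards stronger inhibition in this assay is expected, and it may not exceed the usual scatter. The estimated 1.5-fold lower number from compound 2 to compound 3 (0.18 log units; within the scatter) is small on that reading. Compound 3 is expected at 18000 nM with an estimated range of 6000 nM to 50000 nM in this read-out.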

Compound 3, half-maximal inhibitory concentration: 25000 nM
Estimate against measurement, compound 3: 1.4-fold (0.14 log units) below; low and high end bracket the measured number.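

Lengthening the chain by the change from hydroxycarbamoyl to (hydroxycarbamoyl)methyl, on a saturated chain carbon, three bonds along the chain from an oxygen next to a carbonyl group, gives in this assay a 1.1-fold lower number from compound 2 to compound 3 (0.04 log units; within the scatter), so compound 2 and compound 3 cannot be told apart in this read-out. For the compounds shown here, this is the first size on record for any change at this position, where compound 2 previously stood alone with no step to measure against, and this single step leaves the number within the usual scatter. No supporting measurement is available to explain this result.

Whether a longer chain would stay in the same range is open, since one step sets no trend, and so is what an amine or a carboxylic acid in place of hydroxycarbamoyl would give in this assay. The contribution of the chain as a whole also remains unread, as compound 1 , the shared core with a carboxylic acid and no chain, gives "not determined" (no result reported) and so offers no number to compare with compound 2 or compound 3.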